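The source may hold more compounds than are shown below. What is called first, only, known or untested is meant among the compounds shown, and "the series" means these compounds.

In a functional assay on HeLa cells (Homo sapiens) for inhibition, read by cell counting, with a stated time of 4 days (on this read-out lower numbers stand for stronger inhibition and higher numbers for weaker inhibition), the measured compounds stand as follows:

Compound 1 `C=C(Br)C(=O)Nc1cccc(-c2cn3nc(-c4ccc(CC)cc4)sc3n2)c1`: 3200 nM
Compound 2 `COc1ccc(-c2nn3cc(-c4cccc(N)c4)nc3s2)cc1OC`: 26000 nM
Compound 3 `COc1cccc(-c2nn3cc(-c4cccc(N)c4)nc3s2)c1`: 230000 nM

Compound 1 has the lowest number of the three in this assay, well apart from compound 2 and further still from compound 3. Compound 4 `C=C(Br)C(=O)Nc1cccc(-c2cn3nc(-c4ccc(OC)cc4)sc3n2)c1` differs from compound 1 by one change: methoxy in place of ethyl on an aromatic carbon. Among the measured compounds shown here, the only measured step, an 8.8-fold higher number from compound 2 to compound 3 (0.95 log units; beyond the scatter), concerns hydrogen in place of methoxy, not methoxy in place of ethyl, and occurs in a differently substituted part of the series; it does not directly bear on this change. With no closely matching comparison, the expectation for compound 4 is a number near that of compound 1, with the step of a 1.1-fold lower number from compound 1 to compound 4 (0.03 log units; within the scatter) estimated to lie within the scatter. Compound 4 is therefore estimated at 3000 nM, in the range 900 nM to 10000 nM.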

Compound 4, half-maximal inhibitory concentration: 2300 nM
For compound 4 the middle estimate is 1.3-fold (0.12 log units) above the measured one; the range from low to high includes it.
By their numbers in this assay, from the lowest: compounds 4 and 1 (each within the scatter of the next); then compound 2; then compound 3.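

In this assay, among the compounds shown here, methoxy in place of ethyl gives a 1.4-fold lower number from compound 1 to compound 4 (0.14 log units; within the scatter), the first comparison of these two groups with the rest of the molecule held fixed. At this place on the ring, exchanging a carbon for an oxygen, which adds one hydrogen-bond acceptor by count, does not move the number beyond the scatter. Nothing on hand explains why these two groups read alike.

On these data alone, whether an amine, a carboxylic acid or a longer chain at this place would also leave the number within the scatter remains open.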